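A few compounds are considered here, and "the series" means these few. Any claim that something is new, unique, unknown or untested is made for them only; others in the source may bear on it.

Compound 1, `CCCCCOS(=O)(=O)c1ccc(F)c2ncc(I)cc12`, and compound 2, `NS(=O)(=O)c1ccc(F)c2ncc(I)cc12`, have been measured.

In an assay for inhibition of methylcytosine dioxygenase TET2 (Homo sapiens), read by mass spectrometry, with stated times of 30 min and 1 h (a higher number here means a weaker inhibitor, a lower number a stronger inhibitor), compound 1 gives only a limit, > 200000 nM. In this assay compound 2 gives 86600 nM. Among the compounds with values here, the change an at least 2.3-fold lower number from compound 1 to compound 2 (0.36 log units; beyond the scatter) is the one measured step. Compound 2 thus holds the only number shown, the other entry being a limit (the limit of > 200000 nM in this assay, at which 1 of the 2 values shown sits).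

Compound 3, `COc1cccc(NS(=O)(=O)c2ccc(F)c3ncc(I)cc23)c1`, carries 3-methoxyphenyl in place of hydrogen on a sulfonamide nitrogen. Within the data shown here, no measured step touches the sulfonamide nitrogen, so the step from compound 2 to compound 3 is expected to stay within the scatter, a 1.4-fold lower number from compound 2 to compound 3 (0.16 log units; within the scatter). Compound 3 is expected to give about 60000 nM, between 15000 nM and 200000 nM, in this assay.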

Compound 3, half-maximal inhibitory concentration: > 200000 nM
Compound 3 was reported as a limit; the forecaster's own chance of this, stated with the estimate: 25%; middle value at least 3.3-fold (0.52 log units) away from the limit.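

Within the data shown here, the sulfonamide nitrogen, which no earlier step touched, does not tolerate every change: in this assay, 3-methoxyphenyl in place of hydrogen there gives an at least 2.3-fold higher number from compound 2 to compound 3 (0.36 log units; beyond the scatter). The true size of this loss stays unknown, since compound 3 gives only a limit, and compound 2 remains the only compound with an actual number: the limit of > 200000 nM in this assay, at which 2 of the 3 values shown sit.

The compounds shown leave open whether a small group on this nitrogen, such as methyl, would keep the activity of compound 2. They also leave open whether a plain phenyl would behave like 3-methoxyphenyl.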